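This account rests on a few compounds, and the source may have more. Where it says the series, first, only, none or still open, it means among the compounds named here.

Among the measured compounds shown here, in a functional assay on the whole organism with Rattus norvegicus as the target (a higher number here means that more compound is needed for the effect, a lower number that less compound is needed), three compounds have numbers so far. Compound 1 `CCOC(=O)C(=O)Nc1ccc(N)cc1C#N` gives 1 mg/kg, compound 2 `CCOC(=O)C(=O)Nc1cccc(N(C)C(C)C)c1C#N` gives 0.3 mg/kg, and compound 3 `CCOC(=O)C(=O)Nc1cccc(N2CCCCC2)c1C#N` gives 2.2 mg/kg. Compound 2 therefore has the lowest number of the three, meaning that the least compound is needed for the effect, and its gaps to both others lie beyond the scatter.

Compound 4 `CCOC(=O)C(=O)Nc1cccc(F)c1C#N` changes compound 2 at one place: fluoro in place of isopropyl(methyl)amino on an aromatic carbon. The fluoro group sits on an aromatic carbon, ortho to a cyano group. One measured step also replaces isopropyl(methyl)amino: a 7.3-fold higher number from compound 2 to compound 3 (0.87 log units; beyond the scatter). For the measured compounds named here, that single step shows that replacing this group can raise the number markedly, but no measured compound carries fluoro, so the evidence is thin. Since compound 2 at 0.3 mg/kg already sits lowest, a rise of similar or somewhat smaller size seems most likely. The expected change is a 3.3-fold higher number from compound 2 to compound 4 (0.52 log units; beyond the scatter). For compound 4, the estimated value is 1 mg/kg, with an expected range from 0.25 mg/kg to 4 mg/kg.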

Compound 4, dose for half-maximal effect: 1.2 mg/kg
Compound 4: the middle estimate sits 1.2-fold (0.08 log units) below what was measured, within the range that was stated.
By their numbers in this assay, from the lowest: compound 2; then compounds 1, 4 and 3 (each within the scatter of the next, the first and the last beyond it).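

In this assay, replacing isopropyl(methyl)amino with fluoro (a 4.0-fold higher number from compound 2 to compound 4 (0.60 log units; beyond the scatter)) raises the number, so the low number of compound 2 is now lost with a second, quite different group at this aromatic carbon, one with no nitrogen and no ring. Fluoro and piperidin-1-yl also cannot be told apart here (a 1.8-fold lower number from compound 3 to compound 4 (0.26 log units; within the scatter)), even though they differ widely in heavy atoms, which shows that a large difference in the group entering this position need not give a difference in the number. Nothing measured on these compounds accounts for this result.

The compounds shown leave open whether a smaller open-chain amine such as dimethylamino would keep the low number of compound 2. They also leave open how methoxy, or plain hydrogen at this position, would compare with fluoro.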